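Pyridin-3-yl in place of 4-nitrophenyl

The source may hold more compounds than are shown below. What is called first, only, known or untested is meant among the compounds shown, and "the series" means these compounds.

Compound 1 `CC(=O)N1N=C(c2ccc3ccccc3c2)OC1c1ccc(Br)cc1`: 2.08 ug/mL
Compound 2 `CC(=O)N1N=C(c2ccc3ccccc3c2)OC1c1ccc([N+](=O)[O-])cc1`: 8.1 ug/mL

In a functional assay on HepG2 cells (Homo sapiens) for antiproliferative activity, read by MTT assay, with a stated time of 48 h (on this read-out higher numbers stand for weaker inhibition and lower numbers for stronger inhibition), compound 2 gives 8.1 ug/mL, the higher of the two numbers. Compound 3 `CC(=O)N1N=C(c2ccc3ccccc3c2)OC1c1cccnc1`, not yet measured, carries pyridin-3-yl in place of 4-nitrophenyl on a saturated ring carbon. For the measured compounds named here, the only measured step, a 3.9-fold higher number from compound 1 to compound 2 (0.59 log units; beyond the scatter), is modest and beyond the scatter, but it exchanges a group on an aromatic carbon rather than the whole aromatic ring, so it offers only loose guidance and no firm direction. No step beyond the scatter is therefore expected, and the expected change is a 1.4-fold lower number from compound 2 to compound 3 (0.13 log units; within the scatter). Compound 3 is estimated at 6 ug/mL, with an expected range of 2 ug/mL to 20 ug/mL.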

Compound 3, half-maximal inhibitory concentration: 2.86 ug/mL
Beside the measured number, compound 3's estimate is 2.1-fold (0.32 log units) above it, within the range that was stated.
By their numbers in this assay, from the lowest: compounds 1 and 3 (each within the scatter of the next); then compound 2.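

In this assay, this saturated ring carbon proves open to an exchange of the whole aromatic ring: pyridin-3-yl in place of 4-nitrophenyl gives a 2.8-fold lower number from compound 2 to compound 3 (0.45 log units; beyond the scatter), while pyridin-3-yl in place of 4-bromophenyl gives a 1.4-fold higher number from compound 1 to compound 3 (0.14 log units; within the scatter). A ring with a hetero atom is thus accepted here, and compound 2 alone stands apart from the other two. No evidence at hand accounts for this. Still open, as far as these compounds go, is whether pyridin-4-yl would match pyridin-3-yl at this carbon. From the compounds shown here alone, it is also open whether 4-aminophenyl there, or a longer chain in place of the acetyl group, would shift the number.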